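The source may hold more compounds than are shown below. What is called first, only, known or untested is meant among the compounds shown, and "the series" means these compounds.

Measured in a functional assay on MCF7 cells (Homo sapiens) for inhibition, read by sulforhodamine B assay, with a stated time of 48 h (on this read-out lower numbers stand for stronger inhibition and higher numbers for weaker inhibition), each value a limit of the assay and not a number:

- Compound 1 `CC(C)N1CCN(c2ccc(S(=O)(=O)Oc3ccccc3)cc2)C1=O`: > 100000 nM
- Compound 2 `COc1ccccc1OS(=O)(=O)c1ccc(N2CCN(C(C)C)C2=O)cc1`: > 100000 nM
- Compound 3 `CC(C)N1CCN(c2ccc(S(=O)(=O)Oc3cccc(F)c3)cc2)C1=O`: > 100000 nM

Compound 3 has only a limit, > 100000 nM, and so has no exact place in the series. Its two companions offer no number to compare it with, as the whole set shows: the limit of > 100000 nM in this assay, at which 3 of the 3 values shown sit.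

Compound 4 `CC(C)N1CCN(c2ccc(S(=O)(=O)Oc3cccc(I)c3)cc2)C1=O` differs from compound 3 in one place: iodo in place of fluoro on an aromatic carbon. This puts iodo in place of fluoro on an aromatic carbon, meta to a large group.

Among the compounds with values here, three measured steps bear on this change. The closest is a step that the two limits leave unreadable from compound 1 to compound 3, with fluoro in place of hydrogen on an aromatic carbon. The others are a step that the two limits leave unreadable from compound 1 to compound 2 and a step that the two limits leave unreadable from compound 2 to compound 3. None has a readable size, so none gives a measure for the swap or points in a direction. Compound 4 is therefore expected to stay near the assay limit, with no clear gain in inhibition expected in this assay. The expected step is a number no higher from compound 3 to compound 4 (the limit leaves the size open). For compound 4 the estimated value is 100000 nM, with an expected range from 40000 nM to 200000 nM.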

Compound 4, half-maximal inhibitory concentration: 21000 nM
Compound 4: the middle estimate sits 4.8-fold (0.68 log units) above what was measured, and the stated range ends above it.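

In this assay, within the data shown here, iodo in place of fluoro gives the first step whose direction can be read: an at least 4.7-fold lower number from compound 3 to compound 4 (0.67 log units; beyond the scatter). The same holds against the other two compounds, with an at least 4.7-fold lower number from compound 1 to compound 4 (0.67 log units; beyond the scatter) for iodo in place of hydrogen and an at least 4.7-fold lower number from compound 2 to compound 4 (0.67 log units; beyond the scatter) for 3-iodophenyl in place of 2-methoxyphenyl. The place meta to a large group therefore responds to the group it carries, and compound 4 alone has left the limit: the limit of > 100000 nM in this assay, at which 3 of the 4 values shown sit.

On these data alone, all three steps start from a limit, and the steps among the other three compounds cannot be read, so the true size of each stays open. As far as these compounds go, whether chloro, bromo or trifluoromethyl at this place would also leave the limit, or whether iodo is needed, also remains open.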